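Working notes on solubility across four related compounds

This account rests on a few compounds, and the source may have more. Where it says the series, first, only, none or still open, it means among the compounds named here.

Measured so far:
- Compound 1 `Cc1ccc2c(c1)[n+]([O-])c(NCCN(C)C)n[n+]2[O-]`: in a physicochemical assay for solubility, in the presence of a further agent that is not named here (a lower number here means a less soluble compound, a higher number a more soluble compound), compound 1 gives > 51000000 nM, which is a limit of the assay and not a number.
- Compound 2 `Cc1ccc2c(c1)[n+]([O-])c(NCCN1CCCCC1)n[n+]2[O-]`: in this assay compound 2 gives 45000000 nM.
- Compound 3 `CCc1ccc2c(c1)[n+]([O-])c(NCCN(C)C)n[n+]2[O-]`: in this assay compound 3 gives > 49000000 nM, which is a limit of the assay and not a number.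

Compound 2 differs from compound 1 by one change, (piperidin-1-yl in place of dimethylamino on a saturated chain carbon, two bonds along the chain from a nitrogen on an aromatic ring). In this assay this reads as an at least 1.1-fold lower number from compound 1 to compound 2 (0.05 log units; that floor lies within the scatter), so the two compounds cannot be told apart on this read-out. The value of compound 1 is the one described by the limit of > 51000000 nM in this assay, at which 1 of the 3 values shown sits.

Compound 3 differs from compound 1 at the core, (methyl in place of hydrogen on a saturated chain carbon bound to an aromatic carbon). Its step is a step that the two limits leave unreadable from compound 1 to compound 3, because compound 3 sits at the limit of > 49000000 nM in this assay, at which 1 of the 3 values shown sits, and compound 1 sits at a limit as well, so the size of this step is not readable.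

Compound 4 `CCc1ccc2c(c1)[n+]([O-])c(NCCN1CCCCC1)n[n+]2[O-]` has not yet been measured. It differs from compound 3 by piperidin-1-yl in place of dimethylamino on a saturated chain carbon, two bonds along the chain from a nitrogen on an aromatic ring, the same change that separates compound 1 from compound 2, at the same place on the chain. From compound 3 to compound 4 a step of about an at least 1.1-fold lower number from compound 3 to compound 4 (0.05 log units; that floor lies within the scatter) is expected in this assay, resting on the earlier step of an at least 1.1-fold lower number from compound 1 to compound 2 (0.05 log units; that floor lies within the scatter), which stayed within the scatter. Compound 4 is therefore estimated at 43000000 nM, with a likely range of 25000000 nM to 60000000 nM, while a limit rather than a number remains a real possibility.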

Compound 4, solubility: 39000000 nM
Estimate against measurement, compound 4: 1.1-fold (0.04 log units) above; low and high end bracket the measured number.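

In this assay, piperidin-1-yl in place of dimethylamino gives an at least 1.2-fold lower number from compound 3 to compound 4 (0.09 log units; that floor lies within the scatter), and the same change on the core of compound 1 gives an at least 1.1-fold lower number from compound 1 to compound 2 (0.05 log units; that floor lies within the scatter), so on both cores the change leaves only a floor that lies within the scatter. With piperidin-1-yl in place, the change at the core gives a 1.2-fold lower number from compound 2 to compound 4 (0.06 log units; within the scatter), so compound 2 and compound 4 cannot be told apart on this read-out, while the matching step with dimethylamino, from compound 1 to compound 3, cannot be read. These two pairs do not show that the change has the same size on both cores, since neither floor gives the true size of its step and compound 3 stands at a limit of the assay and not at a number: the limit of > 49000000 nM in this assay, at which 1 of the 4 values shown sits.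

The compounds shown leave open how other amines on the chain, such as morpholin-4-yl or pyrrolidin-1-yl, would read in this assay on either core. They also leave open what a longer chain or a carboxylic acid in place of the amine would do, as only dimethylamino and piperidin-1-yl appear here, on two closely related cores.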